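The source may hold more compounds than are shown below. What is called first, only, known or untested is meant among the compounds shown, and "the series" means these compounds.

Measured so far in an assay on isolated protein (strain Sprague-Dawley) for inhibition of Amine oxidase [flavin-containing] A (Rattus norvegicus), read by spectrophotometry, with a stated time of 5 min, tested at 10 uM; a higher number here means more inhibition at the concentration tested (going by the name of the read-out), a lower number less inhibition:

compound 1, `O=C(O)COc1cc(=O)oc2cc(OCc3cccc(Cl)c3)ccc12`: 0%
compound 2, `CNC(=O)COc1cc(=O)oc2cc(OCc3cccc(Cl)c3)ccc12`: 11%
compound 3, `CCNC(=O)Nc1cc(=O)oc2cc(OCc3cccc(Cl)c3)ccc12`: 0%

Compound 3 stands level with compound 1; together they are the lowest pair of the three numbers. Towards compound 1 the record shows no change at the digits printed from compound 1 to compound 3 (within the scatter), and towards compound 2 it shows a number 11 percentage points lower from compound 2 to compound 3 (beyond the scatter). Within the data shown here, the only step that rose was a number 11 percentage points higher from compound 1 to compound 2 (beyond the scatter), a modest one; the whole series so far moves within a narrow band near the bottom of the scale.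

Compound 4, `O=c1cc(Nc2ccccc2)c2ccc(OCc3cccc(Cl)c3)cc2o1`, is the next member. It differs from compound 3 in one place:

phenyl in place of ethylcarbamoyl on a nitrogen on an aromatic ring

Among the measured compounds shown here, none of the measured steps swaps anything for a phenyl ring on the nitrogen on the aromatic ring, so there is no direct precedent. What the series does show is that every change at this part of the shared core, whether in the chain or in the group attached, moved the read-out in this assay by a modest amount at most or not at all beyond the scatter. The expected step for compound 4 is therefore small, with direction uncertain; a modest rise is estimated as slightly more likely than a fall, since compound 3 already sits at the floor of the scale.

Compound 4 is expected to give 10%, with a range of 0% to 30%. The estimated step of a number 10 percentage points higher from compound 3 to compound 4 (within the scatter) is expected to stay modest.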

Compound 4, a percentage reported as inhibition, at one concentration (the size of the read-out at that concentration, not a potency): 0%
Beside the measured number, compound 4's estimate is 10 percentage points above it; measured number inside the range.
By their numbers in this assay, from the lowest: compounds 1, 3 and 4 (each within the scatter of the next); then compound 2.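

In this assay, on a nitrogen on an aromatic ring, phenyl in place of ethylcarbamoyl gives no change at the digits printed from compound 3 to compound 4 (within the scatter), so an all-carbon aromatic ring with no hydrogen-bond donor or acceptor reads the same here as a chain that carries one of each. The anilino group also leaves the number unmoved against the carboxymethoxy group, with no change at the digits printed from compound 1 to compound 4 (within the scatter), while against the (methylcarbamoyl)methoxy group the record shows a number 11 percentage points lower from compound 2 to compound 4 (beyond the scatter), so compound 2 is now the only one of the four that stands clear of the others, and compounds 1, 3 and 4 cannot be told apart. No information at hand bears on why these changes leave the number where it is.

With three compounds at the bottom of the scale, any real differences among them stay hidden, so neither the ethylcarbamoyl nor the phenyl group can be ranked at this place. Open too, as far as these compounds go, is whether a benzylamino group on the same nitrogen, or a longer chain on the amide nitrogen of compound 2, such as propyl, would lift the read-out further from the bottom of the scale.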